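Dimethylamino in place of 4-ethylpiperazin-1-yl: working notes

The source may hold more compounds than are shown below. What is called first, only, known or untested is meant among the compounds shown, and "the series" means these compounds.

Measured in a functional assay on DLD-1 cells (Homo sapiens) for inhibition, read by MTT assay, with a stated time of 72 h; a lower number here means a stronger inhibitor, a higher number a weaker inhibitor:
- compound 1 `COc1cc(Oc2cccc(Nc3ccccc3)c2)cc(OC)c1CNCc1ccc(F)cc1`: 2650 nM
- compound 2 `CNCc1c(OC)cc(Oc2cccc(Nc3ccccc3)c2)cc1OC`: 11900 nM
- compound 3 `CCN1CCN(Cc2c(OC)cc(Oc3cccc(Nc4ccccc4)c3)cc2OC)CC1`: > 20000 nM

Not yet measured: compound 4 `COc1cc(Oc2cccc(Nc3ccccc3)c2)cc(OC)c1CN(C)C`.

Compound 3 gives > 20000 nM in this assay, and this is a limit of the assay, not a number. The change to compound 4 is dimethylamino in place of 4-ethylpiperazin-1-yl on a saturated chain carbon bound to an aromatic carbon.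

The closest measured comparison is an at least 1.6-fold higher number from compound 2 to compound 3 (0.22 log units; that floor lies within the scatter), and its floor lies within the scatter. The steps of a 4.5-fold higher number from compound 1 to compound 2 (0.65 log units; beyond the scatter) and an at least 7.5-fold higher number from compound 1 to compound 3 (0.87 log units; beyond the scatter) lie beyond the scatter, and both lose the 4-fluorophenyl group, which compound 4 also lacks. A return to the level of compound 1 is therefore not expected. Dimethylamino most resembles the methylamino of compound 2, which gives 11900 nM, so a value near that one is expected.

The expected step is an at least 1.5-fold lower number from compound 3 to compound 4 (0.18 log units; that floor lies within the scatter), towards a lower number, modest in size and possibly not beyond the scatter. In this assay the estimate for compound 4 is 13000 nM, with an expected range from 6000 nM to 20000 nM.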

Compound 4, half-maximal inhibitory concentration: > 20000 nM
Compound 4: no number, only a limit; the forecaster's own chance of this, stated with the estimate: 25%; middle value at least 1.5-fold (0.18 log units) from the limit.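

In this assay compound 4 gives > 20000 nM, which is a limit of the assay and not a number. The step for dimethylamino in place of 4-ethylpiperazin-1-yl cannot be read, so the series gives no order for these two groups on a saturated chain carbon bound to an aromatic carbon: the limit of > 20000 nM in this assay, at which 2 of the 4 values shown sit. Methyl in place of hydrogen on the amine nitrogen gives an at least 1.6-fold higher number from compound 2 to compound 4 (0.22 log units; that floor lies within the scatter), so no clear effect of that change is shown, while dimethylamino in place of (4-fluorobenzyl)amino gives an at least 7.5-fold higher number from compound 1 to compound 4 (0.87 log units; beyond the scatter), which keeps (4-fluorobenzyl)amino clear of this limit by more than the scatter.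

Whether the fluorine of the 4-fluorophenyl group plays any part stays open, as an unsubstituted benzyl group on the amine does not appear among these compounds. Also open, on these data alone, is how a longer chain between the amine nitrogen and that aromatic ring would read in this assay.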